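The source may hold more compounds than are shown below. What is called first, only, known or untested is meant among the compounds shown, and "the series" means these compounds.

Series notes. Compound 1 `CCCCN1CCc2nc(C#Cc3ccccc3)sc2C1` and compound 2 `O=C(C1CC(F)C1)N1CCc2nc(C#Cc3ccccc3)sc2C1` share one core and differ only in the group on the ring amine nitrogen. In an assay on HEK293 cells for positive allosteric modulation of metabotropic glutamate receptor 5 (Homo sapiens), read by FLIPR, with a stated time of 1 h (a higher number here means that more compound is needed for the effect, a lower number that less compound is needed), compound 1 gives 110 nM and compound 2 gives 85 nM. The step of a 1.3-fold lower number from compound 1 to compound 2 (0.11 log units; within the scatter) lies within the scatter, so compound 2 and compound 1 stand level on the two numbers available. Compound 3 `O=C(C1CCCC1)N1CCc2nc(C#Cc3ccccc3)sc2C1` keeps the amide and alters only the ring on the carbonyl: cyclopentyl in place of 3-fluorocyclobutyl on a carbonyl carbon. Going by the values given here, no measured step changes the group on the carbonyl carbon; the one step in hand, butyl to (3-fluorocyclobutyl)carbonyl, is a larger structural change than this one and itself stayed within the scatter. On that basis no step beyond the scatter is expected, and the estimated step of a 1.2-fold higher number from compound 2 to compound 3 (0.07 log units; within the scatter) is small. Compound 3 is expected to give 100 nM in this assay, with a range of 40 nM to 250 nM.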

Compound 3, half-maximal effective concentration: 19 nM
Beside the measured number, compound 3's estimate is 5.3-fold (0.72 log units) above it; the whole stated range lies above it.
By their numbers in this assay, from the lowest: compound 3; then compounds 2 and 1 (each within the scatter of the next).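

In this assay the group on the carbonyl carbon now proves to matter: cyclopentyl in place of 3-fluorocyclobutyl brings a 4.5-fold lower number from compound 2 to compound 3 (0.65 log units; beyond the scatter) even though both groups hold 5 heavy atoms and neither has a hydrogen-bond donor or acceptor. Cyclopentylcarbonyl in place of butyl on the ring amine nitrogen brings a 5.8-fold lower number from compound 1 to compound 3 (0.76 log units; beyond the scatter) whereas the earlier exchange of butyl for (3-fluorocyclobutyl)carbonyl stayed within the scatter, so having an amide at this nitrogen does not by itself set the number. Nothing available explains why this exchange moves the number.

The step from compound 2 to compound 3 changes ring size and removes fluorine together, and plain cyclobutyl would separate the two. On these data alone, how cyclohexyl, phenyl or an open chain such as isopropyl would read on the same carbonyl carbon remains open.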